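Replacing (piperidin-4-yl)methyl with tert-butyl on the core

The source may hold more compounds than are shown below. What is called first, only, known or untested is meant among the compounds shown, and "the series" means these compounds.

In a functional assay on Z-138 cells (Homo sapiens) for antiproliferative activity, with a stated time of 72 h (on this read-out higher numbers stand for weaker inhibition and lower numbers for stronger inhibition), compound 3 `Nc1ncnc2c1c(-c1c[nH]c3ccccc13)nn2CC1CCNCC1` gives 35300 nM and sits within the scatter of its nearest neighbour, compound 1 `CC(C)(CO)Cn1nc(-c2c[nH]c3ccccc23)c2c(N)ncnc21` at 19600 nM on the same scale. Compound 2 `Cn1cc(-c2nn(C(C)(C)C)c3ncnc(N)c23)c2ccccc21` gives > 38200 nM which is a limit and not a number.

The next change leads from compound 3 to compound 4 `CC(C)(C)n1nc(-c2c[nH]c3ccccc23)c2c(N)ncnc21` with tert-butyl in place of (piperidin-4-yl)methyl on an aromatic nitrogen. The counted difference is tert-butyl in place of (piperidin-4-yl)methyl on an aromatic nitrogen in this one place.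

Within the data shown here, one measured step bears on this change, as it also alters the group carried on that nitrogen: a 1.8-fold higher number from compound 1 to compound 3 (0.26 log units; within the scatter) and so stays small. Compound 2 also carries tert-butyl on an aromatic nitrogen and its result is a limit, so a limit for compound 4 remains possible.

Among the measured compounds shown here, with only that small step as a guide, no change beyond the scatter is expected in this assay in either direction. The expected step is a 1.3-fold lower number from compound 3 to compound 4 (0.10 log units; within the scatter) and it rests on very little data. Compound 4 is estimated at 28000 nM with an expected range from 12000 nM to 55000 nM for its value.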

Compound 4, half-maximal inhibitory concentration: 9700 nM
Estimate against measurement, compound 4: 2.9-fold (0.46 log units) above; the measured number lies below the stated range.
By their numbers in this assay, from the lowest: compound 4; then compounds 1 and 3 (each within the scatter of the next). At a limit, above all of these: compound 2.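

Among these compounds, on the aromatic nitrogen of the shared core, tert-butyl gives the first change in this assay that lies beyond the scatter, with a 3.6-fold lower number from compound 3 to compound 4 (0.56 log units; beyond the scatter) and a 2.0-fold lower number from compound 1 to compound 4 (0.31 log units; beyond the scatter), whereas the earlier exchange between the two chain-linked groups stayed small, with a 1.8-fold higher number from compound 1 to compound 3 (0.26 log units; within the scatter). Tert-butyl alone does not account for the result: compound 2 carries it too and differs from compound 4 in one other place, another aromatic nitrogen, where the exchange gives an at least 3.9-fold lower number from compound 2 to compound 4 (0.59 log units; beyond the scatter). Compound 2 gives a limit and not a number, so that step has only a lower bound: the limit of > 38200 nM in this assay, at which 1 of the 4 values shown sits.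

Among the compounds shown here, only three groups are compared on the first nitrogen, and the ring, the heavy-atom count and the hydrogen-bond donor and acceptor counts all change together between (piperidin-4-yl)methyl and tert-butyl, so the data do not separate these features. Still open, going by these compounds, is how isopropyl, cyclopentyl or a chain ending in an amine or a carboxylic acid would fare on that nitrogen, and whether ethyl in place of methyl on the other nitrogen would fall nearer compound 4 or compound 2.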